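Phenyl for methyl on the shared core

The compounds below may be only part of what the source reports. "The series", "measured", "known", "first", "only" and "open" are said of these compounds alone.

Measured so far in an ADME assay on microsomes from liver (Mus musculus) for metabolic stability, with a stated time of 10 min, tested at 0.5 uM; on this read-out lower numbers stand for a less stable compound and higher numbers for a more stable compound 
- compound 1 `Cc1noc(C)c1[C@@H]1C[C@@](C)(c2ccc(F)cc2F)N=C(N)S1` gives 72%
- compound 2 `CCc1noc(C)c1[C@@H]1C[C@@](C)(c2ccc(F)cc2F)N=C(N)S1` gives 41%

Of these two, compound 1 stands highest (72%), and its nearest neighbour is compound 2. Still unmeasured is compound 3 `Cc1noc(-c2ccccc2)c1[C@@H]1C[C@@](C)(c2ccc(F)cc2F)N=C(N)S1`, which has phenyl in place of methyl on an aromatic carbon, next to the ring oxygen (phenyl in place of methyl on an aromatic carbon). Going by the values given here, only one measured step bears on this change, and only loosely, since it concerns a different group on that ring. That step is large (a number 31 percentage points lower from compound 1 to compound 2 (beyond the scatter)). Resting on it alone, a downward step of similar size is expected for compound 3 in this assay, with wide uncertainty. The expected step is a drop beyond the scatter (a number 32 percentage points lower from compound 1 to compound 3 (beyond the scatter)). The estimate for compound 3 is 40% (expected range 15% to 65%).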

Compound 3, percent of the compound remaining: 6%
The estimate for compound 3 lay 34 percentage points above the measured number; measured number below the stated range.
By their numbers in this assay, from the lowest: compound 3; then compound 2; then compound 1.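

In this assay the step of a number 66 percentage points lower from compound 1 to compound 3 (beyond the scatter) shows that the methyl next to the ring oxygen cannot be exchanged for phenyl without a large loss, and compound 3 gives 6% on this read-out. The earlier step of a number 31 percentage points lower from compound 1 to compound 2 (beyond the scatter) concerned a different group on the same ring, so both changes shown on this ring now lower the number, and no compound shown goes against this. No measured evidence accounts for the size of the new step.

On these data alone, how the number moves with the group on this carbon remains open: an ethyl, a cyclopropyl or a pyridine ring there would separate chain length from the presence of an aromatic ring. Also open, as far as these compounds go, is whether an amine or a carboxylic acid on the phenyl would change the result.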